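The source may report more compounds than this note shows. Statements on the series, on what has been measured and on what is new or still open speak of the compounds shown alone.

In a functional assay on MDA-MB-231 cells (Homo sapiens) for cytotoxicity, read by MTT assay, with a stated time of 72 h (on this read-out lower numbers stand for stronger inhibition and higher numbers for weaker inhibition), compound 3 `O=C(CN1CCN(c2nnc(Cc3ccccc3)c3ccccc23)CC1)Nc1cc(C(F)(F)F)ccc1Cl` gives 19500 nM, within the scatter of compound 2 `O=C(CN1CCN(c2nnc(Cc3ccccc3)c3ccccc23)CC1)Nc1ccc(Br)cc1` at 12400 nM and well above compound 1 `Cc1ccc(NC(=O)CN2CCN(c3nnc(Cc4ccncc4)c4ccccc34)CC2)c(C)c1` at 240 nM. Compound 4 `Cc1ccc(NC(=O)CN2CCN(c3nnc(Cc4ccccc4)c4ccccc34)CC2)c(C)c1` differs from compound 3 by 2,4-dimethylphenyl in place of 2-chloro-5-(trifluoromethyl)phenyl on an amide-type nitrogen. Within the data shown here, the only measured step at this place, a 1.6-fold higher number from compound 2 to compound 3 (0.20 log units; within the scatter), stays within the scatter and gives no sign of a large shift. However, compound 1 also carries 2,4-dimethylphenyl on its amide-type nitrogen and gives 240 nM, although it differs from compound 4 elsewhere. A moderate move to a lower number in this assay is therefore expected, with wide uncertainty. The expected change is a 4.9-fold lower number from compound 3 to compound 4 (0.69 log units; beyond the scatter). For compound 4 the estimate is 4000 nM, with an expected range of 500 nM to 20000 nM.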

Compound 4, half-maximal inhibitory concentration: 181000 nM
Compound 4: the middle estimate sits 45-fold (1.66 log units) below what was measured; the measured number lies above the stated range.
By their numbers in this assay, from the lowest: compound 1; then compounds 2 and 3 (each within the scatter of the next); then compound 4.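

With phenyl on the saturated chain carbon, 2,4-dimethylphenyl on the amide-type nitrogen brings a 9.3-fold higher number from compound 3 to compound 4 (0.97 log units; beyond the scatter) and a 15-fold higher number from compound 2 to compound 4 (1.16 log units; beyond the scatter) in this assay. The low number of compound 1 therefore does not carry over with its 2,4-dimethylphenyl alone, as phenyl in place of pyridin-4-yl gives a 750-fold higher number from compound 1 to compound 4 (2.88 log units; beyond the scatter). Nothing on hand explains these steps.

Still open, on these data alone, is whether pyridin-4-yl lowers the number as far with 4-bromophenyl or 2-chloro-5-(trifluoromethyl)phenyl on the amide-type nitrogen. Also open, as far as these compounds go, is how pyridin-3-yl would read on the chain carbon.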